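The source may hold more compounds than are shown below. What is called first, only, known or untested is meant among the compounds shown, and "the series" means these compounds.

Two compounds have been measured in an assay on isolated protein for inhibition of kallikrein-7 (Mus musculus), read by fluorescence, with stated times of 10 min and 30 min; on this read-out higher numbers stand for weaker inhibition and lower numbers for stronger inhibition:

Compound 1, `Cc1cccc(C)c1CC1CN/C(=N\N(C)C)CN(CC(=O)Nc2cccc(-c3cnn(C)c3)c2)C1=O`, gives 3800 nM.
Compound 2, `CN(C)/N=C1/CN(CC(=O)Nc2cccc(-c3cnn(C)c3)c2)C(=O)C(Cc2c(F)cccc2F)CN1`, gives > 30000 nM, which is a limit of the assay and not a number.

Compound 2 therefore stands at the limit of > 30000 nM in this assay, at which 1 of the 2 values shown sits, the weak end of what the assay reports. Within the data shown here, the one measured step reaching it, an at least 7.8-fold higher number from compound 1 to compound 2 (0.89 log units; beyond the scatter), ran toward weaker inhibition and ended in that limit, so compound 2 offers no fixed point from which to count. Compound 3, `CN(C)/N=C1/CN(CC(=O)Nc2cccc(-c3cnn(C)c3)c2)C(=O)C(Cc2ccccc2Cl)CN1`, differs from compound 2 by 2-chlorophenyl in place of 2,6-difluorophenyl on a saturated chain carbon bound to a saturated ring carbon. Among the measured compounds shown here, no measured step covers this exchange; only that single step from the dimethyl to the difluoro analogue bears on it at all. Relative to compound 2, compound 3 is expected to show a step of an at least 1.5-fold lower number from compound 2 to compound 3 (0.17 log units; that floor lies within the scatter) toward stronger inhibition, though another limit remains possible. The estimate for compound 3 in this assay is 20000 nM, within 5000 nM to 60000 nM.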

Compound 3, half-maximal inhibitory concentration: 21000 nM
Compound 3: the middle estimate sits 1.1-fold (0.02 log units) below what was measured; the measured number falls inside the stated range.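

Read in this assay, the exchange of 2,6-dimethylphenyl for a halogen-carrying ring at this position now has a size given by two true numbers and not by a floor: a 5.5-fold higher number from compound 1 to compound 3 (0.74 log units; beyond the scatter). The other step, an at least 1.4-fold lower number from compound 2 to compound 3 (0.15 log units; that floor lies within the scatter), has a floor within the usual scatter, so it does not rank 2-chlorophenyl against 2,6-difluorophenyl. Compound 2 holds a limit and not a number, which is why that step stays open-ended: the limit of > 30000 nM in this assay, at which 1 of the 3 values shown sits.

The compounds shown leave open how a plain phenyl or a 2-methylphenyl would read on this same carbon, and so whether a single methyl group is enough to hold the value of compound 1. Also open, on these data alone, is whether a larger group on the ring, such as methoxy or trifluoromethyl, would give stronger or weaker inhibition here.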